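Bromo for fluoro on the active compound

A few compounds are considered here, and "the series" means these few. Any claim that something is new, unique, unknown or untested is made for them only; others in the source may bear on it.

Measured in a functional assay on NCI-H460 cells (Homo sapiens) for antiproliferative activity, read by MTT assay, with a stated time of 48 h; a higher number here means a weaker inhibitor, a lower number a stronger inhibitor
- compound 1 `COc1cccc(-c2nc3cccc(-c4cc(OC)c(OC)c(OC)c4)c3o2)c1` gives > 25000 nM (a limit)
- compound 2 `COc1ccc(-c2nc3cccc(-c4cc(OC)c(OC)c(OC)c4)c3o2)cc1OC` gives > 25000 nM (a limit)
- compound 3 `COc1cc(-c2cccc3nc(-c4cccc(F)c4)oc23)cc(OC)c1OC` gives 3300 nM (a number)

In this assay, for the measured compounds named here, compound 3 gives 3300 nM as the only actual number, the rest of the series sitting at the limit of > 25000 nM in this assay, at which 2 of the 3 values shown sit, here.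

Compound 4 `COc1cc(-c2cccc3nc(-c4cccc(Br)c4)oc23)cc(OC)c1OC` carries the change bromo in place of fluoro on an aromatic carbon here: 3-fluorophenyl to 3-bromophenyl.

Two measured steps arrive at compound 3. One is an at least 7.5-fold lower number from compound 1 to compound 3 (0.87 log units; beyond the scatter) with fluoro in place of methoxy, and the other is an at least 7.5-fold lower number from compound 2 to compound 3 (0.87 log units; beyond the scatter) with 3-fluorophenyl in place of 3,4-dimethoxyphenyl. Both are beyond the scatter, but each starts from a limit, and neither exchanges one halogen for another. They show that the group on this ring can matter, not how much this change will.

The estimated step is a 1.2-fold higher number from compound 3 to compound 4 (0.08 log units; within the scatter) and it is expected to stay within the scatter, with compound 3 at 3300 nM as the anchor. In this assay compound 4 is estimated at 4000 nM within an expected range from 1300 nM to 13000 nM for a single measurement.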

Compound 4, half-maximal inhibitory concentration: 3800 nM
Beside the measured number, compound 4's estimate is 1.1-fold (0.02 log units) above it, within the range that was stated.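

In this assay, for the compounds shown here, this is the first step at this position with a real number at both ends: a 1.2-fold higher number from compound 3 to compound 4 (0.06 log units; within the scatter), so fluoro and bromo are not told apart here. The 3-bromophenyl compound also stands clear of the methoxy-bearing compounds, with an at least 6.5-fold lower number from compound 2 to compound 4 (0.81 log units; beyond the scatter) and an at least 6.5-fold lower number from compound 1 to compound 4 (0.81 log units; beyond the scatter), so two halogens at this place now give readable numbers. Compound 1 and compound 2 remain limits, not numbers, so those two steps have no fixed size: the limit of > 25000 nM in this assay, at which 2 of the 4 values shown sit.

Going by these compounds, it remains open whether a halogen is needed at all, or whether a nitrile, a trifluoromethyl or an amine on this ring would give a number of the same size. Also open is how far these values depend on the rest of the shared core, which is the same in all the compounds shown.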